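Furan to Hydroxyphenyl on the Pyrazoline Carbon: An Expectation

The source may hold more compounds than are shown below. What is called first, only, known or untested is meant among the compounds shown, and "the series" means these compounds.

Of the compounds shown here, three sharing the nitrocatechol core have been measured in an assay for inhibition of Catechol O-methyltransferase (Rattus norvegicus), read by fluorescence and spectrophotometry; a lower number here means a stronger inhibitor, a higher number a weaker inhibitor. Compound 1 `O=C(/C=C/c1ccoc1)c1cc(O)c(O)c([N+](=O)[O-])c1` gives 290 nM. Compound 2 `O=C(/C=C/c1nccs1)c1cc(O)c(O)c([N+](=O)[O-])c1` gives 240 nM. Compound 3 `CC(=O)N1N=C(c2cc(O)c(O)c([N+](=O)[O-])c2)CC1c1ccco1` gives 180 nM. For the measured compounds named here, the one single-point step measured so far is a 1.2-fold lower number from compound 1 to compound 2 (0.08 log units; within the scatter), a heteroaryl swap on a chain carbon that left the number essentially unchanged. Compound 3 stands within the scatter of both compound 2 and compound 1, so the three numbers are not distinguishable from one another.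

Compound 4 `CC(=O)N1N=C(c2cc(O)c(O)c([N+](=O)[O-])c2)CC1c1cccc(O)c1` differs from compound 3 by 3-hydroxyphenyl in place of furan-2-yl on a saturated ring carbon. Going by the values given here, no measured step covers a furan to hydroxyphenyl exchange on the saturated ring carbon, and the only comparable data, the heteroaryl swap from compound 1 to compound 2, stayed within the scatter. The expected change is therefore no change at the digits printed from compound 3 to compound 4 (within the scatter), with no direction favoured. Compound 4 is estimated to give 180 nM in this assay, within a range from 60 nM to 550 nM.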

Compound 4, half-maximal inhibitory concentration: 75 nM
Estimate against measurement, compound 4: 2.4-fold (0.38 log units) above, within the range that was stated.
By their numbers in this assay, from the lowest: compound 4; then compounds 3, 2 and 1 (each within the scatter of the next).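

For the compounds shown here, on the saturated ring carbon of the five-membered non-aromatic ring, 3-hydroxyphenyl in place of furan-2-yl gives a 2.4-fold lower number from compound 3 to compound 4 (0.38 log units; beyond the scatter) in this assay, the first step in this set to lie beyond the scatter, though only modestly. Going by these compounds alone, the earlier step on the chain carbon, a 1.2-fold lower number from compound 1 to compound 2 (0.08 log units; within the scatter), stayed within the scatter, so only this change shows that the group exchanged can move the number. The change brought in a six-membered aromatic ring of carbon only and a hydrogen-bond donor together, and no measurement shown here bears on why the number fell.

On these data alone, it remains open whether the step follows the hydroxyl or the larger ring, which a plain phenyl would help to separate. Also open, as far as these compounds go, is how an amine or a carboxylic acid in place of that hydroxyl would read.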